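The source may report more compounds than this note shows. Statements on the series, on what has been measured and on what is new or still open speak of the compounds shown alone.

The measured compounds and their values:

compound 1, `COc1ccc(F)cc1CNCCCNc1ccnc2cc(CCC(C)C)ccc12`: 9.47
compound 2, `COc1ccc(F)cc1CNCCCNc1ccnc2cc(CCc3ccccc3)ccc12`: 9.47
compound 3, `COc1ccc(F)cc1CNCCCNc1ccnc2cc(Cc3ccccc3)ccc12`: 9.47

Three compounds share one core and differ only in the group carried on the saturated chain carbon bound to an aromatic carbon. In a physicochemical assay for acid dissociation, compound 1 gives 9.47, compound 2 gives 9.47 and compound 3 gives 9.47. The steps among them are no change at the digits printed from compound 1 to compound 2 (within the scatter), no change at the digits printed from compound 1 to compound 3 (within the scatter) and no change at the digits printed from compound 2 to compound 3 (within the scatter). Compound 3 therefore stands level with compound 1 and compound 2 in this assay.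

Compound 4, `COc1ccc(F)cc1CNCCCNc1ccnc2cc(CC3CCCCC3)ccc12`, has not yet been measured. It differs from compound 3 in one place: cyclohexyl in place of phenyl on a saturated chain carbon bound to an aromatic carbon. Among the compounds with values here, the steps that bear on this change are those from compound 1 to compound 3 and from compound 2 to compound 3, in which phenyl replaced a saturated group at the same place, and both lay within the scatter. On that basis the step from compound 3 to compound 4 is expected to be no change at the digits printed from compound 3 to compound 4 (within the scatter), none beyond the scatter. Compound 4 is estimated at 9.47, within 9.17 to 9.77.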

Compound 4, acid dissociation constant: 9.47
Compound 4: middle estimate and measured number agree at the digits printed, within the range that was stated.
By their numbers in this assay, from the lowest: compounds 1, 2, 3 and 4 (each within the scatter of the next).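

In this assay, cyclohexyl in place of phenyl gives no change at the digits printed from compound 3 to compound 4 (within the scatter), so a non-aromatic ring of six carbons now joins the aromatic one at this place, on a saturated chain carbon bound to an aromatic carbon. Cyclohexyl in place of benzyl gives no change at the digits printed from compound 2 to compound 4 (within the scatter), and cyclohexyl in place of isobutyl gives no change at the digits printed from compound 1 to compound 4 (within the scatter), which puts all four groups level at the digits printed. Nothing at hand accounts for this reading.

Every group shown at this place is built of carbon alone, so it stays open whether an amine or a carboxylic acid there would also leave the number level. Changes elsewhere on the shared core, such as replacing the fluorine or the methoxy group, also remain open.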